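Trimming the carboxyalkyl group of compound 2

The compounds below may be only part of what the source reports. "The series", "measured", "known", "first", "only" and "open" are said of these compounds alone.

In a functional assay on Fem-X cells (Homo sapiens) for cytotoxicity, read by MTT assay, with a stated time of 72 h (on this read-out lower numbers stand for stronger inhibition and higher numbers for weaker inhibition), compound 1 (`CC1=CCC[C@H]2[C@](C)(CC3=CC(=O)C=C(NCCC(=O)O)C3=O)[C@@H](C)CC[C@]12C`) gives 20200 nM, and compound 2 (`CC1=CCC[C@H]2[C@](C)(CC3=CC(=O)C=C(N[C@@H](C(=O)O)C(C)C)C3=O)[C@@H](C)CC[C@]12C`) gives 11400 nM. For the measured compounds named here, compound 2 therefore stands level with the only other measured compound. Compound 3 (`CC1=CCC[C@H]2[C@](C)(CC3=CC(=O)C=C(N[C@@H](C)C(=O)O)C3=O)[C@@H](C)CC[C@]12C`) carries 1-carboxyethyl in place of 1-carboxy-2-methylpropyl on an amine nitrogen. Going by the values given here, the one measured step bearing on this change, a 1.8-fold lower number from compound 1 to compound 2 (0.25 log units; within the scatter), also alters that substituent and stays within the scatter, so no step beyond the scatter is expected in this assay. The expected step is a 1.2-fold higher number from compound 2 to compound 3 (0.09 log units; within the scatter). The estimate for compound 3 is 14000 nM, with an expected range of 6500 nM to 30000 nM.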

Compound 3, half-maximal inhibitory concentration: 10300 nM
Compound 3: the middle estimate sits 1.4-fold (0.13 log units) above what was measured; measured number inside the range.
By their numbers in this assay, from the lowest: compounds 3, 2 and 1 (each within the scatter of the next).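

In this assay, shortening 1-carboxy-2-methylpropyl to 1-carboxyethyl on the amine nitrogen gives only a small difference (a 1.1-fold lower number from compound 2 to compound 3 (0.04 log units; within the scatter)), which lies within the scatter. Setting 1-carboxyethyl in place of 2-carboxyethyl also stays within the scatter (a 2.0-fold lower number from compound 1 to compound 3 (0.29 log units; within the scatter)), so these three carboxyalkyl groups cannot be told apart at this position. No supporting data explain this level reading.

Still open, from the compounds shown here alone, is whether the carboxylic acid itself matters, and whether a methyl ester, a primary amide or a much longer chain at this nitrogen would move the number beyond the scatter.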